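Swapping a Methyl for a Fluorophenyl Ring: An Expectation

The source may report more compounds than this note shows. Statements on the series, on what has been measured and on what is new or still open speak of the compounds shown alone.

Of the compounds shown here, three built on a shared core have been tested in an ADME assay on microsomes from liver (Rattus norvegicus), read by LC-MS, using NADPH, with a stated time of 30 min, tested at 1 uM; a higher number here means that more of the compound is left, a lower number that less of the compound is left. Compound 3 `Cc1nc(N)nc(N[C@@H](C)c2c(-c3ccccc3)c(=O)n3cc(F)ccc3c2C)c1C#N` gives 91%, the highest of the three numbers. Compound 2 `C[C@H](Nc1nc(N)nc(N)c1C#N)c1c(-c2ccccc2)c(=O)n2cc(F)ccc2c1-c1ccc(F)cc1` gives 77%, which lies beyond the scatter below compound 3. Compound 1 `Cc1nc(N)nc(N[C@@H](C)c2cc3ccc(F)cn3c(=O)c2-c2ccccc2)c1C#N` gives 41%, the furthest from compound 3. Among the measured compounds shown here, the only step between two compounds that differ in a single place is a number 50 percentage points higher from compound 1 to compound 3 (beyond the scatter), where a methyl takes the place of a hydrogen on an aromatic carbon.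

Compound 4 `Cc1nc(N)nc(N[C@@H](C)c2c(-c3ccccc3)c(=O)n3cc(F)ccc3c2-c2ccc(F)cc2)c1C#N` is compound 3 with one change: 4-fluorophenyl in place of methyl on an aromatic carbon. For the measured compounds named here, no measured step covers this exchange of a methyl for a ring. The step from compound 1 to compound 3 shows that this position can move the number a long way, but it runs from hydrogen to methyl, not from methyl onward. Compound 2 carries the same 4-fluorophenyl at this place yet differs from compound 4 elsewhere, so its number is only a loose guide. On this basis compound 4 is expected to sit somewhat below compound 3, a step of a number 13 percentage points lower from compound 3 to compound 4 (beyond the scatter), at the edge of the scatter. The estimate for compound 4 in this assay is 78%, with a range from 58% to 93%.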

Compound 4, percent of the compound remaining: 85%
Compound 4: middle estimate off by 7 percentage points, on the low side, within the range that was stated.
By their numbers in this assay, from the lowest: compound 1; then compounds 2, 4 and 3 (each within the scatter of the next, the first and the last beyond it).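

In this assay, replacing methyl with 4-fluorophenyl adds a whole aromatic ring at this aromatic carbon, taking the group from 1 heavy atom to 7, yet the result is a number 6 percentage points lower from compound 3 to compound 4 (within the scatter), so the two groups cannot be told apart here. Set against hydrogen at the same carbon, the ring gives a number 44 percentage points higher from compound 1 to compound 4 (beyond the scatter), which shows that this position tolerates a group far larger than methyl and that the clear divide in this small set lies between hydrogen and either substituent, while the exchange of amino for methyl at a different place on the molecule gives a number 8 percentage points higher from compound 2 to compound 4 (within the scatter) and so also stays inside the usual variation. No measurement available here explains why either substituent stands apart from hydrogen.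

The compounds shown leave open whether an amine, a carboxylic acid or a longer alkyl chain at this aromatic carbon would behave like methyl and 4-fluorophenyl or fall back toward hydrogen. They also leave open whether a plain phenyl ring would match 4-fluorophenyl, so the part played by the fluorine on that ring cannot be judged.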